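Amino side chain on the hydroxy series

The compounds below may be only part of what the source reports. "The series", "measured", "known", "first", "only" and "open" are said of these compounds alone.

Compound 1 (`CCN(CC)CCNC(=O)c1ccc(C(CC)(CC)c2ccc(OCC(=O)C(C)(C)C)c(C)c2)n1CC`) gives 690 nM in a functional assay on MCF7 cells (Homo sapiens), read by MTT assay, with a stated time of 48 h; a higher number here means a weaker inhibitor, a lower number a stronger inhibitor
Compound 2 (`CCn1c(C(=O)NCCCN(C)C)ccc1C(CC)(CC)c1ccc(OCC(=O)C(C)(C)C)c(C)c1`) gives 340 nM
Compound 3 (`CCN(CC)CCNC(=O)c1ccc(C(CC)(CC)c2ccc(OCC(O)C(C)(C)C)c(C)c2)n1CC`) gives 690 nM

Compound 3 shares the highest number of the three with compound 1, and compound 2 sits lower. Compound 4 (`CCn1c(C(=O)NCCN)ccc1C(CC)(CC)c1ccc(OCC(O)C(C)(C)C)c(C)c1`) carries amino in place of diethylamino on a saturated chain carbon, two bonds along the chain from an amide-type nitrogen. The nearest evidence at that place is the modest step on going from diethylamino to (dimethylamino)methyl (a 2.0-fold lower number from compound 1 to compound 2 (0.31 log units; beyond the scatter)). Replacing (tert-butyl)carbonyl with 1-hydroxy-2,2-dimethylpropyl gave no shift beyond the scatter (no change at the digits printed from compound 1 to compound 3 (within the scatter)), so the first step may carry over to compound 3. Going by the values given here, no measured compound carries amino itself, which leaves the size uncertain. A modest move in this assay is expected (a 1.4-fold lower number from compound 3 to compound 4 (0.16 log units; within the scatter)). Compound 4 is estimated at 480 nM, within a range of 190 nM to 1200 nM overall.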

Compound 4, half-maximal inhibitory concentration: 5.9 nM
Beside the measured number, compound 4's estimate is 81-fold (1.91 log units) above it, outside the stated range (below it).
By their numbers in this assay, from the lowest: compound 4; then compound 2; then compounds 1 and 3 (each within the scatter of the next).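

In this assay, the place on a saturated chain carbon, two bonds along the chain from an amide-type nitrogen, proves far more sensitive than the earlier pair showed. Amino in place of diethylamino gives a 120-fold lower number from compound 3 to compound 4 (2.07 log units; beyond the scatter), whereas (dimethylamino)methyl in place of diethylamino gave only a 2.0-fold lower number from compound 1 to compound 2 (0.31 log units; beyond the scatter). Nothing available accounts for the size of this step.

As far as these compounds go, whether methylamino or a longer chain such as 3-aminopropyl would keep this low number remains open. So does whether amino gives the same step with (tert-butyl)carbonyl in place of 1-hydroxy-2,2-dimethylpropyl.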